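Cytotoxicity of three bis(trifluoromethyl)benzamide sulfonamides

The source may hold more compounds than are shown below. What is called first, only, known or untested is meant among the compounds shown, and "the series" means these compounds.

Compound 1 `COc1cc(NC(=O)c2cc(C(F)(F)F)cc(C(F)(F)F)c2)ccc1NS(C)(=O)=O`: > 250000 nM
Compound 2 `CCS(=O)(=O)Nc1ccc(NC(=O)c2cc(C(F)(F)F)cc(C(F)(F)F)c2)cc1OC`: > 250000 nM
Compound 3 `COc1cc(NC(=O)c2cc(C(F)(F)F)cc(C(F)(F)F)c2)ccc1NS(=O)(=O)C(F)(F)F`: > 250000 nM

In an ADME assay on RAW264.7 cells (Mus musculus) for cytotoxicity, read by MTT assay, with a stated time of 48 h (on this read-out lower numbers stand for stronger inhibition and higher numbers for weaker inhibition), compound 1 gives > 250000 nM, which is a limit of the assay rather than a number. Compound 2 likewise reaches only a limit, > 250000 nM. Compound 3 also gives a limit, > 250000 nM. Compound 2 therefore stands at the same limit as its two neighbours, and all three values sit there (the limit of > 250000 nM in this assay, at which 3 of the 3 values shown sit). The steps between them cannot be read: a step that the two limits leave unreadable from compound 1 to compound 2, a step that the two limits leave unreadable from compound 1 to compound 3 and a step that the two limits leave unreadable from compound 2 to compound 3 each lie between two limits.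

Compound 4 `CCS(=O)(=O)Nc1ccc(NC(=O)c2cc(C(F)(F)F)cc(C(F)(F)F)c2)cc1Cl` differs from compound 2 by chloro in place of methoxy on an aromatic carbon. For the measured compounds named here, no measured step bears directly on a change at this position; the three steps between the measured compounds, all unreadable, concern only the sulfonyl substituent. Going by the values given here, the only guidance is that every measured compound, compound 2 included, sits at the limit.

Compound 4 is therefore expected to behave like compound 2, with a step of about a number no higher from compound 2 to compound 4 (the limit leaves the size open) in this assay, most likely a limit again. The estimate for compound 4 is 250000 nM, within 80000 nM to 800000 nM.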

Compound 4, half-maximal inhibitory concentration: 64100 nM
Compound 4: the middle estimate sits 3.9-fold (0.59 log units) above what was measured, and the stated range ends above it.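

In this assay, for the compounds shown here, the aromatic carbon ortho to a (ethylsulfonyl)amino group proves to be a place where the read-out can move, something the earlier compounds could not show: all their steps concern the sulfonyl substituent and none can be read. Chloro in place of methoxy at this carbon gives an at least 3.9-fold lower number from compound 2 to compound 4 (0.59 log units; beyond the scatter) and brings the read-out off the limit, so a single change on the aromatic ring is enough to produce a measurable cytotoxic effect within this series. As far as these compounds go, the full size of the step stays open, and the other three values share one limit: the limit of > 250000 nM in this assay, at which 3 of the 4 values shown sit.

The compounds shown leave open whether chloro would have the same effect alongside a methylsulfonyl or trifluoromethylsulfonyl group in place of the ethylsulfonyl group. They also leave open whether the shift depends on chloro itself or on the loss of methoxy, a question that a hydrogen, a fluoro, a bromo, a methyl or a nitrile at this carbon would help to settle.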